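This account rests on a few compounds, and the source may have more. Where it says the series, first, only, none or still open, it means among the compounds named here.

Compound 1 `Cc1nc2c(cnn2-c2ccccc2)c(=O)n1C1CCCCCC1`: "not determined" (no result reported)
Compound 2 `Cc1nc2c(cnn2-c2ccccc2)c(=O)n1N1CCCCC1`: 2800 nM
Compound 3 `Cc1nc2c(cnn2CC2CCCCC2)c(=O)n1-c1ccc(Cl)cc1`: > 100000 nM

Three compounds share a core; they were tested in an in vitro functional assay on cells for antagonist activity at metabotropic glutamate receptor 5 (Homo sapiens), read by FLIPR and calcium flux; a lower number here means a stronger inhibitor, a higher number a weaker inhibitor. For compound 1 no result was recorded. Compound 2 gives a measured number in this assay, 2800 nM. For compound 3 this assay reports only a limit, > 100000 nM, so its inhibition was too weak to be measured as a number. Compound 3 is the one compound sitting at the limit of > 100000 nM in this assay, at which 1 of the 3 values shown sits, and among the shown values it is the only one without a single number.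

Compound 4 `Cc1nc2c(cnn2-c2cccc(Cl)c2)c(=O)n1-c1ccc(Cl)cc1` has not yet been measured. It differs from compound 3 in one place: 3-chlorophenyl in place of cyclohexylmethyl on an aromatic nitrogen. Within the data shown here, no measured pair shows this exact change, so the size of the step is uncertain. Compound 2, which carries a phenyl on that nitrogen, gives 2800 nM. Compound 3, with cyclohexylmethyl there, gave only a limit in this assay. On that basis the step from compound 3 to compound 4 is expected to be toward stronger inhibition, beyond the scatter, an at least 16-fold lower number from compound 3 to compound 4 (1.22 log units; beyond the scatter). Compound 4 is therefore estimated at 6000 nM, within a range from 800 nM to 60000 nM.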

Compound 4, half-maximal inhibitory concentration: > 100000 nM
Compound 4 gave a limit, no number; the forecaster's own chance of this, stated with the estimate: 35%; middle value at least 16-fold (1.22 log units) from the limit.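

Compound 3 and compound 4 both stop at a limit in this assay, so no step between them can be read: the limit of > 100000 nM in this assay, at which 2 of the 4 values shown sit.

The compounds shown leave open whether 3-chlorophenyl and cyclohexylmethyl on that aromatic nitrogen differ in inhibition at all, and by how much.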